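Anilide ring substitution in a cyclopropane diamide series

The compounds below may be only part of what the source reports. "The series", "measured", "known", "first", "only" and "open" are said of these compounds alone.

compound 1 `CN(C)C(=O)c1cc2cnc(Nc3ccc(NC(=O)C4(C(=O)Nc5ccccc5)CC4)cc3)nc2n1C1CCCC1` — 75%
compound 2 `CN(C)C(=O)c1cc2cnc(Nc3ccc(NC(=O)C4(C(=O)Nc5cccc(Cl)c5)CC4)cc3)nc2n1C1CCCC1` — 8.3%
compound 3 `CN(C)C(=O)c1cc2cnc(Nc3ccc(NC(=O)C4(C(=O)Nc5cccc(Br)c5)CC4)cc3)nc2n1C1CCCC1` — 20.2%

In a functional assay on A549 cells (Homo sapiens) for inhibition, read by CCK-8 assay, with a stated time of 72 h, tested at 1 uM (a higher number here means more inhibition of growth at the concentration tested, a lower number less inhibition of growth), compound 1 gives 75%, compound 2 gives 8.3% and compound 3 gives 20.2%. Compound 3 stands second highest of the three values: the step from its nearest neighbour reads a number 11.9 percentage points higher from compound 2 to compound 3 (beyond the scatter), and the step from the highest value reads a number 54.8 percentage points lower from compound 1 to compound 3 (beyond the scatter).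

Compound 4 `CN(C)C(=O)c1cc2cnc(Nc3ccc(NC(=O)C4(C(=O)Nc5ccc(O)cc5)CC4)cc3)nc2n1C1CCCC1` differs from compound 3 by 4-hydroxyphenyl in place of 3-bromophenyl on an amide-type nitrogen. Among the compounds with values here, no measured step covers a hydroxyl on this ring, so the expectation rests on the halogen steps alone. Both a number 66.7 percentage points lower from compound 1 to compound 2 (beyond the scatter) and a number 54.8 percentage points lower from compound 1 to compound 3 (beyond the scatter) are large and point the same way: a halogen on this ring cost most of the growth inhibition. Taking the bromine away again is therefore expected to return a good part of what was lost, while the entering hydroxyl is an unknown that may add to or take from that recovery. A large rise in this assay is expected, with wide uncertainty around it.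

For compound 4 the expected step is a number 29.8 percentage points higher from compound 3 to compound 4 (beyond the scatter). Compound 4 is thus estimated at 50%, in the range 15% to 85%.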

Compound 4, percent growth inhibition at one concentration: 93.6%
The estimate for compound 4 lay 43.6 percentage points below the measured number; the whole stated range lies below it.
By their numbers in this assay, from the lowest: compound 2; then compound 3; then compound 1; then compound 4.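

Working notes on the anilide ring: in this assay substitution on this ring does not by itself cost growth inhibition, since the hydroxyl on this ring gives the only rise over compound 1 in the series (a number 18.6 percentage points higher from compound 1 to compound 4 (beyond the scatter)), and compound 4 stands above all three earlier compounds. The steps from the halogenated compounds (a number 73.4 percentage points higher from compound 3 to compound 4 (beyond the scatter); a number 85.3 percentage points higher from compound 2 to compound 4 (beyond the scatter)) change both the group and where it sits, as the names 3-bromophenyl, 3-chlorophenyl and 4-hydroxyphenyl show, so their large size cannot be assigned to either change alone. Nothing available explains why this ring responds so differently to the hydroxyl and to the halogens.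

Still open, as far as these compounds go, is whether the placement or the identity of the substituent decides the outcome, which a hydroxyl placed as the halogens are in compound 2 and compound 3, or a halogen placed as the hydroxyl is in compound 4, would separate. Also open, from the compounds shown here alone, is whether the rise needs the free hydroxyl itself or would also appear with a methoxy group, an amine or a carboxylic acid on the same ring.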